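This account rests on a few compounds, and the source may have more. Where it says the series, first, only, none or still open, it means among the compounds named here.

Three ureas have been measured in an ADME assay on the whole organism with Oryza sativa as the target, tested at 1 uM; a higher number here means a weaker effect of the compound at the concentration tested, a lower number a stronger effect. Compound 1 `C[C@@H](NC(=O)Nc1cccc(F)c1)c1ccccc1` gives 95%. Compound 2 `C[C@@H](NC(=O)Nc1ccc(F)cc1)c1ccccc1` gives 96%; the difference between the cores of compound 1 and compound 2 is not broken down here. Compound 3 `C[C@@H](NC(=O)Nc1cccc(F)c1F)c1ccccc1` gives 99%, and the step of a number 4 percentage points higher from compound 1 to compound 3 (within the scatter) comes with the change (fluoro in place of hydrogen on an aromatic carbon). Compound 4 `C[C@@H](NC(=O)Nc1ccc(F)cc1F)c1ccccc1` has not yet been measured; it carries the same kind of change from compound 2, namely (fluoro in place of hydrogen on an aromatic carbon), though the places differ: in compound 3 the entering fluoro is ortho to a fluoro group, whereas in compound 4 it is meta to a fluoro group. For compound 4 a step of a number 2 percentage points higher from compound 2 to compound 4 (within the scatter) is expected, because the measured step of a number 4 percentage points higher from compound 1 to compound 3 (within the scatter) stayed within the scatter. Compound 4 is therefore estimated at 98%, between 92% and 100%.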

Compound 4, a percentage reported as activity, at one concentration (the size of the read-out at that concentration, not a potency): 100%
Compound 4: the middle estimate sits 2 percentage points below what was measured, and the stated range covers the measured number.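

In this assay the added fluoro gives a number 4 percentage points higher from compound 2 to compound 4 (within the scatter), and the change reads the same on both cores: the same change on two cores in this assay, a number 4 percentage points higher (within the scatter) from compound 1 to compound 3 and a number 4 percentage points higher (within the scatter) from compound 2 to compound 4, 0 percentage points apart, within the scatter of two such steps.
So, across these two pairs, carrying the change from one core to the other shows no visible difference. Both steps lie within the scatter, however, so this does not show that the fluoro has any effect of its own in this assay, and two pairs say nothing about other cores.

From the compounds shown here alone, all four compounds carry only fluoro on the aromatic ring, so it remains open whether a chlorine, a methoxy group or an amine there would move the number beyond the scatter. Going by these compounds, whether changes away from that ring, such as a longer chain in place of the methyl group, would do so also remains open.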